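The source may hold more compounds than are shown below. What is called first, only, known or untested is meant among the compounds shown, and "the series" means these compounds.

Working notes on the series. Compound 1 `Cc1nc(-c2cccc(NC(=O)C3CCCN(C(=O)c4cc(C(F)(F)F)cc(C(F)(F)F)c4)C3)c2)cs1` gives 1% in an ADME assay on PC-3 cells (Homo sapiens) for cytotoxicity, read by WST assay, tested at 100 uM; on this read-out higher numbers stand for more inhibition at the one concentration tested (going by the name of the read-out) and lower numbers for less inhibition. Among the three measured numbers this is the second highest: compound 3 `COCc1cccc(C(=O)N2CCCC(C(=O)Nc3ccc(Cl)cc3)C2)c1` gives 0%, a value within the scatter of compound 1, while compound 2 `O=C(Nc1ccc(Cl)cc1)C1CCCN(C(=O)c2cccc(-c3nccs3)c2)C1` gives 32%, the furthest away and beyond the scatter. Within the data shown here, the only step between measured compounds that differ in one place is a number 32 percentage points lower from compound 2 to compound 3 (beyond the scatter), methoxymethyl in place of 1,3-thiazol-2-yl on an aromatic carbon.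

Compound 4 `O=C(Nc1cccc(N2CCCC2=O)c1)C1CCCN(C(=O)c2cc(C(F)(F)F)cc(C(F)(F)F)c2)C1` is to be measured in this assay. It differs from compound 1 by 2-oxopyrrolidin-1-yl in place of 2-methyl-1,3-thiazol-4-yl on an aromatic carbon. Among the measured compounds shown here, no measured step covers this exchange. The step from compound 2 to compound 3 also removes a five-membered aromatic ring from an aromatic carbon of the shared core, but puts methoxymethyl in its place rather than another ring, so it is only a loose guide. Compound 1 already sits near the floor of the read-out, leaving little room for a fall. The expected step is a number 2 percentage points higher from compound 1 to compound 4 (within the scatter), none beyond the scatter. Compound 4 is therefore estimated at 3%, in the range 0% to 15%.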

Compound 4, a percentage reported as inhibition, at one concentration (the size of the read-out at that concentration, not a potency): 0%
Compound 4: middle estimate off by 3 percentage points, on the high side; the range from low to high includes it.
By their numbers in this assay, from the lowest: compounds 3, 4 and 1 (each within the scatter of the next); then compound 2.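

On an aromatic carbon of a six-membered aromatic ring of carbon only, meta to a large group, 2-oxopyrrolidin-1-yl in place of 2-methyl-1,3-thiazol-4-yl gives a number 1 percentage points lower from compound 1 to compound 4 (within the scatter) in this assay. Among these compounds, this is the first reading of an exchange at this position, and it shows that a five-membered non-aromatic ring and a five-membered aromatic ring cannot be told apart here while both compounds stay near the bottom of the read-out. No measurement at hand offers a reason for this result.

Left open is whether an amine or a carboxylic acid on this aromatic carbon would lift the number off the bottom of the read-out. Also open, from the compounds shown here alone, is whether this exchange would give a step beyond the scatter on a compound starting from a higher number.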